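A few compounds are considered here, and "the series" means these few. Any claim that something is new, unique, unknown or untested is made for them only; others in the source may bear on it.

Working notes on the series in a functional assay on A549 cells (Homo sapiens) for cytotoxicity, read by MTT assay, with a stated time of 72 h; a lower number here means a stronger inhibitor, a higher number a weaker inhibitor. Compound 1 (`O=C(N/N=C/c1ccc(F)cc1)Nc1cc2c(Nc3ccc(F)c(Cl)c3)ncnc2cc1O[C@H]1CCOC1`) gives 35100 nM, compound 2 (`O=C(N/N=C/c1cccc(Br)c1)Nc1cc2c(Nc3ccc(F)c(Cl)c3)ncnc2cc1O[C@H]1CCOC1`) gives 10700 nM and compound 3 (`N#Cc1ccc(/C=N/NC(=O)Nc2cc3c(Nc4ccc(F)c(Cl)c4)ncnc3cc2O[C@H]2CCOC2)cc1`) gives 29100 nM. Compound 3 stands at the upper end of these three numbers, and the step from the 3-bromophenyl member reads a 2.7-fold higher number from compound 2 to compound 3 (0.43 log units; beyond the scatter).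

Compound 4 (`O=C(N/N=C/c1ccc([N+](=O)[O-])cc1)Nc1cc2c(Nc3ccc(F)c(Cl)c3)ncnc2cc1O[C@H]1CCOC1`) has nitro in place of cyano on an aromatic carbon, para to a large group: nitro in place of cyano on an aromatic carbon. For the measured compounds named here, no nitro compound has been measured yet, so the evidence is indirect. The closest measured change, also made on that aromatic carbon, is cyano in place of fluoro, and it stays within the scatter: a 1.2-fold lower number from compound 1 to compound 3 (0.08 log units; within the scatter). The larger step, a 3.3-fold lower number from compound 1 to compound 2 (0.52 log units; beyond the scatter), brings in 3-bromophenyl in place of 4-fluorophenyl and bears less directly on a change that keeps the 4-substituted ring.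

No step beyond the scatter is therefore expected in this assay. The expected step is a 1.0-fold lower number from compound 3 to compound 4 (0.02 log units; within the scatter). For compound 4 the estimated value is 28000 nM, with an expected range of 12000 nM to 60000 nM.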

Compound 4, half-maximal inhibitory concentration: 31200 nM
For compound 4 the middle estimate is 1.1-fold (0.05 log units) below the measured one, and the stated range covers the measured number.
By their numbers in this assay, from the lowest: compound 2; then compounds 3, 4 and 1 (each within the scatter of the next).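

In this assay, nitro on the aromatic carbon para to a large group gives a third substituent there that does not separate from the others: cyano to nitro reads (a 1.1-fold higher number from compound 3 to compound 4 (0.03 log units; within the scatter)), and fluoro to nitro reads (a 1.1-fold lower number from compound 1 to compound 4 (0.05 log units; within the scatter)). Compounds 1, 3 and 4 thus form a flat set across these three groups, and compound 2 goes against it, with the 3-bromophenyl to 4-nitrophenyl comparison reading (a 2.9-fold higher number from compound 2 to compound 4 (0.46 log units; beyond the scatter)). Nothing at hand gives a cause for either reading.

Still open, as far as these compounds go, is whether the lower number of compound 2 goes with bromo itself or with its place on the ring, a question a 4-bromophenyl member would address. Also open, from the compounds shown here alone, is whether an amine or a carboxylic acid on the same aromatic carbon would leave this flat reading intact.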